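The source may report more compounds than this note shows. Statements on the series, on what has been measured and on what is new or still open speak of the compounds shown alone.

In a functional assay on Caco-2 cells (Homo sapiens) for antiproliferative activity, read by MTT assay, with a stated time of 48 h (on this read-out lower numbers stand for stronger inhibition and higher numbers for weaker inhibition), compound 1 `CCn1c(C(=O)NCCN(C)C)ccc1C(CC)(CC)c1ccc(OCCC(O)(CC)CC)c(C)c1` gives 1140 nM. Compound 2 `C=CCN(C)C(=O)c1ccc(C(CC)(CC)c2ccc(OCCC(O)(CC)CC)c(C)c2)n1CC` gives > 50000 nM, which is a limit of the assay and not a number. Among the compounds with values here, the one measured step at this place is an at least 43-fold higher number from compound 1 to compound 2 (1.64 log units; beyond the scatter), a large change that puts allyl(methyl)amino in place of (2-(dimethylamino)ethyl)amino on a carbonyl carbon. Compound 3 `CCn1c(C(=O)Nc2cccc(C(F)(F)F)c2)ccc1C(CC)(CC)c1ccc(OCCC(O)(CC)CC)c(C)c1`, not yet measured, changes the same place again, with (3-(trifluoromethyl)phenyl)amino in place of allyl(methyl)amino on a carbonyl carbon. Within the data shown here, the step of an at least 43-fold higher number from compound 1 to compound 2 (1.64 log units; beyond the scatter) shows that this assay responds strongly to this place, but it is the only guide and concerns a different group. A moderate move towards lower numbers is therefore expected, although compound 3 could also remain at the limit. The expected step is an at least 3.3-fold lower number from compound 2 to compound 3 (0.52 log units; beyond the scatter). For compound 3 the estimate is 15000 nM, with an expected range from 3000 nM to 50000 nM.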

Compound 3, half-maximal inhibitory concentration: > 50000 nM
Compound 3: only a limit was reported; the forecaster's own chance of this, stated with the estimate: 35%; at least 3.3-fold (0.52 log units) between middle value and limit.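

In this assay, the hydrogen-bond donor and the aromatic ring brought in by (3-(trifluoromethyl)phenyl)amino do not recover the activity of compound 1, and the amide-type nitrogen now carrying 3-(trifluoromethyl)phenyl gives an at least 43-fold higher number from compound 1 to compound 3 (1.64 log units; beyond the scatter). The step between compound 2 and compound 3 cannot be read, as both end at the same point: the limit of > 50000 nM in this assay, at which 2 of the 3 values shown sit. Of the three groups shown on this carbonyl carbon, only (2-(dimethylamino)ethyl)amino gives a readable value, with compound 1 at 1140 nM.

The compounds shown leave open which part of the (2-(dimethylamino)ethyl)amino group matters, the dimethylamino group or the ethyl chain that carries it. A 2-hydroxyethylamino group, or a longer chain ending in the same dimethylamino group, would separate the two.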